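A few compounds are considered here, and "the series" means these few. Any claim that something is new, unique, unknown or untested is made for them only; others in the source may bear on it.

Within the data shown here, compound 2, `COc1ccc(/C=C/C(=O)NS(=O)(=O)c2ccc(Cl)cc2)cc1`, gives 5.3 ug/mL in a functional assay on B16-F10 cells (Mus musculus) for antiproliferative activity, read by ELISA and MTT assay, with a stated time of 48 h (a lower number here means a stronger inhibitor, a higher number a weaker inhibitor), the lowest of the two numbers measured so far; compound 1, `COc1ccc(/C=C/C(=O)NS(=O)(=O)c2ccc(C)cc2)cc1`, gives 12.2 ug/mL. Among the measured compounds shown here, the only step measured, a 2.3-fold lower number from compound 1 to compound 2 (0.36 log units; beyond the scatter), concerns the ring that is left untouched in compound 3, `O=C(/C=C/c1ccc([N+](=O)[O-])cc1)NS(=O)(=O)c1ccc(Cl)cc1`. The change to compound 3 is nitro in place of methoxy on an aromatic carbon. For the measured compounds named here, no measured step bears on this change directly, so the account rests on what the one recorded step shows: the step from compound 1 to compound 2 moved the number by a modest amount beyond the scatter after a single exchange on an aromatic carbon. A step of similar size, or none beyond the scatter, is therefore expected here, with the direction uncertain, and the expected step is a 1.2-fold lower number from compound 2 to compound 3 (0.07 log units; within the scatter). Compound 3 is accordingly expected to give 4.5 ug/mL, with a range from 2 ug/mL to 10 ug/mL.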

Compound 3, half-maximal inhibitory concentration: 13.7 ug/mL
The estimate for compound 3 lay 3.0-fold (0.48 log units) below the measured number, outside the stated range (above it).
By their numbers in this assay, from the lowest: compound 2; then compounds 1 and 3 (each within the scatter of the next).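

In this assay, nitro in place of methoxy on an aromatic carbon para to a large group gives a rise (a 2.6-fold higher number from compound 2 to compound 3 (0.41 log units; beyond the scatter)), so the number also responds to a change on this ring. Among these compounds, the one earlier step (a 2.3-fold lower number from compound 1 to compound 2 (0.36 log units; beyond the scatter)) lay on the other ring and went the opposite way. With the chloro group of compound 2 held in place, methoxy at this position gives the lower number of the two groups compared, and nothing at hand bears on why the number rose.

The compounds shown leave open whether the rise belongs to nitro or to the loss of methoxy, and how an amine, a hydroxyl or a plain hydrogen would read at this place. They also leave open whether this step would keep its size with methyl in place of chloro on the other ring.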